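The source may report more compounds than this note shows. Statements on the series, on what has been measured and on what is new or still open speak of the compounds shown alone.

Of the compounds shown here, two have been measured in a functional assay on CCRF-CEM cells (Homo sapiens), read by cell counting, with a stated time of 72 h; a higher number here means a weaker inhibitor, a lower number a stronger inhibitor. Compound 1 `COc1ccc(/C=C/c2ccc(F)cc2)cc1` gives 156 ug/mL in this assay. Compound 2 `Cc1ccc(/C=C/c2ccc(N(C)C)cc2)cc1` stands only at a limit: in this assay compound 2 reports > 200 ug/mL, which is a bound of the assay and not a number, as set out in the limit of > 200 ug/mL in this assay, at which 1 of the 2 values shown sits. Compound 3 `COc1ccc(/C=C/c2ccc(C)cc2)cc1` is not yet measured; it carries methoxy in place of dimethylamino on an aromatic carbon, that is, methoxy in place of dimethylamino on an aromatic carbon. Within the data shown here, because compound 2 sits at the limit, no measured step fixes the size of this change. Compound 3 shares its methoxy with compound 1, which gives 156 ug/mL in this assay. Any step in this assay is expected to be small, within the scatter or a little below the limit. Compound 3 is expected to give 170 ug/mL in this assay, with a range of 100 ug/mL to 250 ug/mL, and the expected step is an at least 1.1-fold lower number from compound 2 to compound 3 (0.07 log units; that floor lies within the scatter).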

Compound 3, half-maximal inhibitory concentration: > 200 ug/mL
Compound 3: only a limit was reported; the forecaster's own chance of this, stated with the estimate: 40%; at least 1.1-fold (0.07 log units) between middle value and limit.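

In this assay compound 3 gives > 200 ug/mL, which is a limit of the assay and not a number. With compound 2 also at a limit, the step for methoxy in place of dimethylamino on an aromatic carbon cannot be read, and this change has no measured size. Among these compounds, the one readable change is methyl in place of fluoro on an aromatic carbon with the methoxy kept, which gives an at least 1.2-fold higher number from compound 1 to compound 3 (0.10 log units; that floor lies within the scatter), and most of the series now rests on a single bound: the limit of > 200 ug/mL in this assay, at which 2 of the 3 values shown sit.

Going by these compounds, how far compound 2 and compound 3 truly lie beyond that bound stays open, as does whether any group at this place moves the number beyond the scatter. A hydroxyl, a primary amine or a carboxylic acid on that aromatic carbon would test this.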